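Aryl swap on the shared core: compound 2 to compound 3

The source may hold more compounds than are shown below. What is called first, only, known or untested is meant among the compounds shown, and "the series" means these compounds.

Compound 2 `COc1c(OCCCCN2CCN(C)CC2)cc(O)c2c(=O)cc(-c3ccc(C(F)(F)F)cc3)oc12` gives 2980 nM in a functional assay on MCF7 cells (Homo sapiens) for cytotoxicity, read by MTT assay, with a stated time of 72 h; a higher number here means a weaker inhibitor, a lower number a stronger inhibitor. Compound 1 `COc1ccc(-c2cc(=O)c3c(O)cc(OCCCCN4CCN(C)CC4)c(OC)c3o2)cc1` gives 3980 nM in this assay. Compound 2 holds the lower of the two numbers, but the step of a 1.3-fold lower number from compound 1 to compound 2 (0.13 log units; within the scatter) lies within the scatter, so the two compounds cannot be ordered on these data. Compound 3 `COc1ccccc1-c1cc(=O)c2c(O)cc(OCCCCN3CCN(C)CC3)c(OC)c2o1` has not yet been measured. It differs from compound 2 by 2-methoxyphenyl in place of 4-(trifluoromethyl)phenyl on an aromatic carbon. Among the compounds with values here, the only measured step that bears on this change is the one from compound 1 to compound 2, a 1.3-fold lower number from compound 1 to compound 2 (0.13 log units; within the scatter), which exchanges the same two groups in the opposite direction and stayed within the scatter. Within the data shown here, compound 3, however, carries its methoxy as 2-methoxyphenyl, an arrangement that no measured compound shares, so that step is only a partial guide. On this basis no step beyond the scatter is expected in either direction; the expected step from compound 2 to compound 3 is a 1.2-fold higher number from compound 2 to compound 3 (0.07 log units; within the scatter). Compound 3 is therefore estimated at 3500 nM in this assay, with a range from 1200 nM to 10000 nM.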

Compound 3, half-maximal inhibitory concentration: 5430 nM
Compound 3: the middle estimate sits 1.6-fold (0.19 log units) below what was measured; the measured number falls inside the stated range.
By their numbers in this assay, from the lowest: compounds 2, 1 and 3 (each within the scatter of the next).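

In this assay, within the data shown here, the first reading on where the methoxy sits on this aryl group is a 1.4-fold higher number from compound 1 to compound 3 (0.13 log units; within the scatter): exchanging 4-methoxyphenyl for 2-methoxyphenyl stays within the scatter. The exchange of 4-(trifluoromethyl)phenyl for 2-methoxyphenyl, a 1.8-fold higher number from compound 2 to compound 3 (0.26 log units; within the scatter), also stays within the scatter, so the three aryl groups tried at this carbon, next to the ring oxygen, cannot be ordered on these data, and each single exchange shown here leaves the number in the same range. No measurement is available that could account for these results or connect them to any property of the groups.

The compounds shown leave open whether an aryl group carrying an amine or a carboxylic acid, or a saturated ring in place of the aryl group, would produce a step beyond the scatter at this carbon. They also leave open whether a longer chain in place of the one on the shared core would change the number in this assay, and whether any of these aryl exchanges would read the same with a different chain.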